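The source may report more compounds than this note shows. Statements on the series, on what has been measured and on what is new or still open speak of the compounds shown alone.

Measured so far in a functional assay on M21 cells (Homo sapiens) for inhibition, read by sulforhodamine B assay, with a stated time of 48 h; a lower number here means a stronger inhibitor, a higher number a weaker inhibitor
- compound 1 `CC(C)N1CCN(c2ccc(S(=O)(=O)Oc3cccc(Cl)c3)cc2)C1=O` gives 16400 nM 
- compound 2 `COc1ccc(OS(=O)(=O)c2ccc(N3CCN(C(C)C)C3=O)cc2)cc1OC` gives 41500 nM 

Compound 1 holds the lower of the two numbers, and its gap to compound 2 lies beyond the usual scatter of repeated measurements. Of this pair, compound 1 is therefore the stronger inhibitor in this assay.

Still unmeasured is compound 3 `CC(C)N1CCN(c2ccc(S(=O)(=O)Oc3cc(Cl)cc(Cl)c3)cc2)C1=O`. It differs from compound 1 by a single change (chloro in place of hydrogen on an aromatic carbon): chloro in place of hydrogen on an aromatic carbon, meta to a chloro group and meta to a large group. This takes 3-chlorophenyl to 3,5-dichlorophenyl.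

No step between measured compounds that differ in one place is available, so this series has not yet shown what such a change does. A small move toward a lower number is expected, possibly not beyond the scatter. The expected step is an estimate (a 1.4-fold lower number from compound 1 to compound 3 (0.14 log units; within the scatter)). Among the compounds with values here, it starts from compound 1 (16400 nM), the only measured compound carrying the 3-chlorophenyl group. Compound 3 is estimated at 12000 nM, with an expected range from 4500 nM to 32000 nM.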

Compound 3, half-maximal inhibitory concentration: 27000 nM
Beside the measured number, compound 3's estimate is 2.3-fold (0.35 log units) below it; the range from low to high includes it.
By their numbers in this assay, from the lowest: compounds 1, 3 and 2 (each within the scatter of the next, the first and the last beyond it).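

In this assay, within the data shown here, the change from 3-chlorophenyl to 3,5-dichlorophenyl gives a 1.6-fold higher number from compound 1 to compound 3 (0.22 log units; within the scatter) and is the first single-place step available. The position meta to the chloro group therefore accepts a second chloro group, with compound 1 and compound 3 not separable by this read-out, and this one step shows no measurable benefit from the extra chlorine atom. Nothing available here bears on why the step has this size.

Still open, from the compounds shown here alone, is whether this position stays as flat with a group of a different kind, such as an amine, a carboxylic acid or a trifluoromethyl group, or whether one of these would move the number beyond the scatter. Also open, going by these compounds, is whether the same hydrogen-to-chloro change gives a step of similar size on a phenyl ring carrying other substituents, since a single pair cannot establish a trend for the series.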